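The source may report more compounds than this note shows. Statements on the series, on what has been measured and on what is new or still open speak of the compounds shown alone.

Measured so far:
Compound 1 `O=c1[nH]cc(S(=O)(=O)Nc2cccc(-c3cn(-c4ccccc4Cl)nn3)c2)c(=O)[nH]1`: 4030 nM
Compound 2 `Cc1ccccc1-n1cc(-c2ccc(NS(=O)(=O)c3c[nH]c(=O)[nH]c3=O)cc2)nn1`: 14500 nM

In a functional assay on HepG2 cells (Homo sapiens) for antiproliferative activity, read by MTT assay, with a stated time of 24 h (a higher number here means a weaker inhibitor, a lower number a stronger inhibitor), compound 2 gives the highest number of the two, and compound 1 sits below it by more than the usual scatter. Compound 3 `O=c1[nH]cc(S(=O)(=O)Nc2ccc(-c3cn(-c4cccc(F)c4)nn3)cc2)c(=O)[nH]1` keeps the core of compound 2 and differs in one place: 3-fluorophenyl in place of 2-methylphenyl on an aromatic nitrogen. Within the data shown here, no measured pair shows this change alone, so its effect is unknown. The step from compound 2 to compound 3 is expected to be modest, probably within the scatter, perhaps leaning toward a lower number: a 1.6-fold lower number from compound 2 to compound 3 (0.21 log units; within the scatter). Compound 3 is therefore estimated at 9000 nM, with a range from 2500 nM to 30000 nM.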

Compound 3, half-maximal inhibitory concentration: > 20000 nM
Compound 3 was reported as a limit; the forecaster's own chance of this, stated with the estimate: 10%; at least 2.2-fold (0.34 log units) between middle value and limit.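

In this assay, compound 3 is reported only as a limit of the assay, not as a number: the limit of > 20000 nM in this assay, at which 1 of the 3 values shown sits. Among these compounds, putting 3-fluorophenyl in place of 2-methylphenyl on the aromatic nitrogen gives an at least 1.3-fold higher number from compound 2 to compound 3 (0.13 log units; that floor lies within the scatter), the first reading of any change at this place. This swap brings no lower number, but the true size of the rise cannot be read, and its floor alone does not separate the two compounds.

From the compounds shown here alone, what a plain phenyl or a 3-methylphenyl would give on this nitrogen stays open, so the effect of the fluorine or methyl itself cannot be told apart from that of its place on the phenyl.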